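A few compounds are considered here, and "the series" means these few. Any claim that something is new, unique, unknown or untested is made for them only; others in the source may bear on it.

Compound 1 `COc1ccc(-c2c(C(=O)c3cc(OC)c(OC)c(OC)c3)sc3ccccc23)cc1`: 1600 nM
Compound 2 `COc1ccccc1-c1c(C(=O)c2cc(OC)c(OC)c(OC)c2)sc2ccccc12`: 2900 nM

Both values come from a functional assay on Jurkat cells (Homo sapiens) for antiproliferative activity, read by MTT assay, with a stated time of 72 h (a higher number here means a weaker inhibitor, a lower number a stronger inhibitor), and compound 2 stands within the scatter of compound 1. Within the data shown here, the only measured step, 2-methoxyphenyl in place of 4-methoxyphenyl, is small: a 1.8-fold higher number from compound 1 to compound 2 (0.26 log units; within the scatter).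

Compound 3 `COc1ccc(-c2c(C(=O)c3cc(OC)c(OC)c(OC)c3)sc3ccccc23)c(OC)c1` is compound 2 with one change, 2-methoxyphenyl to 2,4-dimethoxyphenyl: methoxy in place of hydrogen on an aromatic carbon. Among the measured compounds shown here, no measured step shows a methoxy group being added, so the small step above is the only guide, and no change beyond the scatter is expected in this assay. The estimate means a 1.3-fold lower number from compound 2 to compound 3 (0.10 log units; within the scatter). For compound 3 the expected value is 2300 nM, with an estimated range of 800 nM to 6500 nM.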

Compound 3, half-maximal inhibitory concentration: 4000 nM
The estimate for compound 3 lay 1.7-fold (0.24 log units) below the measured number, within the range that was stated.
By their numbers in this assay, from the lowest: compounds 1, 2 and 3 (each within the scatter of the next, the first and the last beyond it).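

In this assay, methoxy entering para to a large group on the 2-methoxyphenyl ring gives a 1.4-fold higher number from compound 2 to compound 3 (0.14 log units; within the scatter). Among these compounds, measured against the 4-methoxyphenyl ring, the same 2,4-dimethoxyphenyl ring gives a 2.5-fold higher number from compound 1 to compound 3 (0.40 log units; beyond the scatter), the first step in this short series to pass the scatter, though only modestly. Neither step shows any gain from carrying a second methoxy group on this ring, and nothing available here bears on why. From the compounds shown here alone, whether an amine, a hydroxyl group or a longer chain such as ethoxy would behave like methoxy at this position stays open.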